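A few compounds are considered here, and "the series" means these few. Any claim that something is new, unique, unknown or untested is made for them only; others in the source may bear on it.

The measured compounds in an assay on membranes from brain for displacement of a labelled ligand from Neuronal acetylcholine receptor; alpha4/beta2 (Rattus norvegicus), with a stated time of 3 h; a higher number here means a weaker inhibitor, a lower number a stronger inhibitor:
- compound 1 `C(=C1\CCCN=C1c1cccnc1)\c1ccccc1` gives 850 nM
- compound 2 `CC(=O)Oc1ccccc1/C=C1\CCCN=C1c1cccnc1` gives 700 nM

Compound 1 has the highest of the two numbers in this assay, and compound 2 is its nearest neighbour, the pair showing a 1.2-fold lower number from compound 1 to compound 2 (0.08 log units; within the scatter). Compound 3 `CC(C)(C)C(=O)Oc1ccc(/C=C2\CCCN=C2c2cccnc2)cc1` has not yet been measured. It differs from compound 1 by ((tert-butyl)carbonyl)oxy in place of hydrogen on an aromatic carbon. Among the compounds with values here, only one measured step bears on this kind of change: the step of a 1.2-fold lower number from compound 1 to compound 2 (0.08 log units; within the scatter), in which acetoxy took the place of hydrogen on an aromatic carbon, stayed within the scatter. Within the data shown here, the group entering in compound 3 is a larger ester, ((tert-butyl)carbonyl)oxy, and it sits para to a large group, a place for which no measured step exists; the account has no evidence that a larger acyloxy group at that place would shift the number much. The account therefore expects no step beyond the scatter, and a 1.1-fold lower number from compound 1 to compound 3 (0.03 log units; within the scatter) is the expected step. For compound 3 the estimate in this assay is 800 nM, with a range from 300 nM to 2500 nM.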

Compound 3, inhibition constant: 830 nM
For compound 3 the middle estimate is 1.0-fold (0.02 log units) below the measured one; measured number inside the range.
By their numbers in this assay, from the lowest: compounds 2, 3 and 1 (each within the scatter of the next).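

In this assay, within the data shown here, the entry of ((tert-butyl)carbonyl)oxy on an aromatic carbon, para to a large group, gives a 1.0-fold lower number from compound 1 to compound 3 (0.01 log units; within the scatter) and so supplies the first reading at this place. Acetoxy, the smaller ester, gave a 1.2-fold lower number from compound 1 to compound 2 (0.08 log units; within the scatter) on the same ring, so the two esters measured so far, including one with 7 heavy atoms and no ring, both leave the number within the scatter of compound 1. The data offer no measured basis for explaining why this larger ester stays within the scatter.

Both entering groups are esters, so the compounds shown leave open whether a hydroxyl group, an amine or a carboxylic acid at the same place would also stay within the scatter of compound 1. They also leave open whether a step beyond the scatter would appear with an ester bearing a longer chain or a ring, or with ((tert-butyl)carbonyl)oxy at another place on this ring.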